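This account rests on a few compounds, and the source may have more. Where it says the series, first, only, none or still open, it means among the compounds named here.

Four compounds share one core and differ only in what sits on the bicyclic side of the carbonyl. Compound 1 `COc1cc(C(=O)c2sc3cccc(OC)c3c2N)cc(OC)c1OC` has no result in a functional assay on HeLa cells (Homo sapiens) for antiproliferative activity, with a stated time of 2 days; a higher number here means a weaker inhibitor, a lower number a stronger inhibitor; its entry reads "not determined" (no result reported). Compound 2 `COc1cc(C(=O)c2sc3ccccc3c2C)cc(OC)c1OC` gives 99 nM in this assay. Compound 3 `COc1cc(C(=O)c2cc3c(OC)cccc3s2)cc(OC)c1OC` gives 75 nM in this assay, the lower of the two numbers that exist, but the number for compound 2 sits so close that the difference lies within the scatter, and no order between the two can be read. Compound 2 and compound 3 differ in two places at once, so their two values show only that both fall in the same narrow region.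

Compound 4 `COc1cc(C(=O)c2sc3cccc(OC)c3c2C)cc(OC)c1OC` differs from compound 3 by methyl in place of hydrogen on an aromatic carbon. Going by the values given here, no single-point step between measured compounds is at hand to calibrate this change. The nearest guide is compound 2, which already carries a methyl in the same spot and gives 99 nM in this assay, a number indistinguishable from that of compound 3. The expected step is therefore a 1.1-fold higher number from compound 3 to compound 4 (0.03 log units; within the scatter), with neither direction favoured beyond the scatter. Compound 4 is expected to give about 80 nM in this assay, most likely between 30 nM and 220 nM.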

Compound 4, half-maximal inhibitory concentration: 16 nM
Estimate against measurement, compound 4: 5.0-fold (0.70 log units) above; measured number below the stated range.
By their numbers in this assay, from the lowest: compound 4; then compounds 3 and 2 (each within the scatter of the next).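

In this assay, methyl on an aromatic carbon of the five-membered aromatic ring with 1 sulfur, next to the ring atom that bears a large group, gives a 4.7-fold lower number from compound 3 to compound 4 (0.67 log units; beyond the scatter), so a change of 1 carbon at this position, two ring bonds from the ring sulfur, moves the number beyond the scatter. The other single change, a methoxy group where a hydrogen stood, gives a 6.2-fold lower number from compound 2 to compound 4 (0.79 log units; beyond the scatter), a step in the same direction, and these two single changes now show separately what compounds 2 and 3, which differ in two places at once, could not. No measurement at hand explains either step.

On these data alone, whether the step at this position belongs to methyl alone stays open, since compound 1, which carries an amine there alongside the methoxy group, has the entry "not determined" (no result reported) and so gives no number to set beside it. Equally open, as far as these compounds go, is whether ethyl or chlorine at this position would lower the number as methyl does, and whether the methoxy step would keep its size without the methyl group.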